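Putting a Carbamoyl Group Back on the Ring Nitrogen

The compounds below may be only part of what the source reports. "The series", "measured", "known", "first", "only" and "open" are said of these compounds alone.

Three compounds share one core and differ only in the group carried by an amine nitrogen in a ring. Compound 1 `COc1ccc(-c2cnc3nc(N)nc(N4CCN(C(=O)NCc5ccccc5)CC4)c3n2)cc1OC` gives 18 nM in a functional assay on cells (T-cell, Homo sapiens) for inhibition; a lower number here means a stronger inhibitor, a higher number a weaker inhibitor. Compound 2 `COc1ccc(-c2cnc3nc(N)nc(N4CCN(C(=O)Nc5ccc(C)cc5)CC4)c3n2)cc1OC` gives 0.8 nM, and compound 3 `COc1ccc(-c2cnc3nc(N)nc(N4CCN(Cc5ccccc5F)CC4)c3n2)cc1OC` gives 700 nM. Compound 3 therefore has the highest number of the three: a 39-fold higher number from compound 1 to compound 3 (1.59 log units; beyond the scatter), and an 880-fold higher number from compound 2 to compound 3 (2.94 log units; beyond the scatter), both well beyond the scatter. Compound 4 `COc1ccc(-c2cnc3nc(N)nc(N4CCN(C(=O)Nc5cccc(C)c5)CC4)c3n2)cc1OC` is the next step: (3-methylphenyl)carbamoyl in place of 2-fluorobenzyl on an amine nitrogen in a ring. Both measured steps that end at compound 3 traded a carbamoyl group for 2-fluorobenzyl and raised the number sharply, the larger one starting from the arylcarbamoyl of compound 2. Reversing that trade, now with (3-methylphenyl)carbamoyl, is expected to lower the number by a large step, a 350-fold lower number from compound 3 to compound 4 (2.54 log units; beyond the scatter). Compound 4 is estimated at 2 nM, within a range from 0.5 nM to 10 nM, near compound 2, whose methyl-bearing arylcarbamoyl gave 0.8 nM.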

Compound 4, half-maximal inhibitory concentration: 7 nM
Beside the measured number, compound 4's estimate is 3.5-fold (0.54 log units) below it; low and high end bracket the measured number.
By their numbers in this assay, from the lowest: compound 2; then compound 4; then compound 1; then compound 3.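

In this assay, the large drop seen on replacing 2-fluorobenzyl with a carbamoyl group (a 100-fold lower number from compound 3 to compound 4 (2.00 log units; beyond the scatter)) now holds for a second methylphenyl group, so it does not depend on the exact arrangement in compound 2. Where the methyl sits on the phenyl ring still counts, since moving from 4-methylphenyl to 3-methylphenyl costs potency (an exact change that gives an 8.8-fold higher number from compound 2 to compound 4 (0.94 log units; beyond the scatter)). A phenyl ring placed directly on the amide-type nitrogen again gives a lower number than benzyl (shown by a 2.6-fold lower number from compound 1 to compound 4 (0.41 log units; beyond the scatter)), though by a much smaller step than in compound 2.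

No data shown here offer a reason for these differences. As far as these compounds go, it remains open how a plain phenyl, or a chlorine or methoxy group in place of the methyl, would read at this position.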